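The source may report more compounds than this note shows. Statements on the series, on what has been measured and on what is new or still open speak of the compounds shown alone.

Measured in a functional assay on A549 cells (Homo sapiens) for inhibition, read by MTT assay, with a stated time of 72 h; on this read-out lower numbers stand for stronger inhibition and higher numbers for weaker inhibition:
Compound 1 `COc1cc(O)c(CC=C(C)C)c(O)c1C(=O)/C=C/c1ccc(C(F)(F)F)cc1`: 11100 nM
Compound 2 `COc1cc(OC)c(C(=O)/C=C/c2ccc(O)cc2)c(OC)c1`: 49400 nM

Of these two results, compound 2 has the higher number, 49400 nM, which makes it the weaker inhibitor of the pair. Its gap to compound 1 lies beyond the usual scatter.

Compound 3 `COc1cc(OC)c(C(=O)/C=C/c2ccc(Cl)cc2)c(OC)c1` has not yet been measured. It keeps the core of compound 2 and differs in one place: chloro in place of hydroxy on an aromatic carbon. In short, 4-hydroxyphenyl becomes 4-chlorophenyl.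

Among the compounds with values here, no measured pair shows this change, so the expectation is tentative: a modest step toward a lower number in this assay. A result within the scatter of compound 2 would not be surprising. The estimated value for compound 3 is 22000 nM, with an expected range from 7000 nM to 65000 nM. This estimate corresponds to an expected step of a 2.2-fold lower number from compound 2 to compound 3 (0.35 log units; beyond the scatter).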

Compound 3, half-maximal inhibitory concentration: 13300 nM
Compound 3: middle estimate off by 1.7-fold (0.22 log units), on the high side; the measured number falls inside the stated range.
By their numbers in this assay, from the lowest: compounds 1 and 3 (each within the scatter of the next); then compound 2.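

Within the data shown here, this is the first comparison here that changes only one place, and in this assay replacing hydroxy with chloro gives a 3.7-fold lower number from compound 2 to compound 3 (0.57 log units; beyond the scatter) on the shared core. The position para to a large group therefore responds to what sits on it: the hydroxy, which counts as a hydrogen-bond donor and acceptor, can give way to a chloro, which counts as neither, and inhibition grows stronger rather than being lost. Nothing measured here accounts for this step.

A single swap cannot separate the effect of removing the hydroxy from that of adding the chloro. Going by these compounds, how an amine, a bromo or a carboxylic acid at this same position would compare with these two groups remains open.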